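The compounds below may be only part of what the source reports. "The series", "measured", "known", "first", "only" and "open" are said of these compounds alone.

Working notes on the amide series, cytotoxicity read-out.

In an ADME assay on BJ cells (Homo sapiens) for cytotoxicity, read by CellTiter-Glo and resazurin assay, with a stated time of 72 h (on this read-out lower numbers stand for an effect already at smaller amounts and higher numbers for an effect only at larger amounts of compound), compound 1 `CC(C)N(Cc1cccc(OCCCCCC(=O)O)c1)C(=O)c1ccc(-c2cccc(-c3ccccc3)c2)cc1` returns only a limit of the assay, > 26000 nM. Compound 2 `CC(C)COc1cccc(-c2ccc(C(=O)N(Cc3cccc(OCCCCCC(=O)O)c3)C(C)C)cc2)c1` likewise comes back as a limit, > 26000 nM. Compound 3 `CCOC(=O)CCCCCOc1cccc(CN(C(=O)c2ccc(-c3cccc(-c4ccccc4)c3)cc2)C(C)C)c1` also stands at a limit, > 26000 nM. Because all three values sit at the limit of > 26000 nM in this assay, at which 3 of the 3 values shown sit, the two steps joining them, a step that the two limits leave unreadable from compound 1 to compound 2 and a step that the two limits leave unreadable from compound 1 to compound 3, carry no readable size, and compound 3 cannot be placed against either partner beyond the shared limit.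

Compound 4 `CCOC(=O)CCCCCOc1cccc(CN(C(=O)c2ccc(-c3cc(OC)cc(OC)c3)cc2)C(C)C)c1` is still to be measured in this assay. It differs from compound 3 in one place: 3,5-dimethoxyphenyl in place of 3-phenylphenyl on an aromatic carbon. Among the measured compounds shown here, no measured step touches this part of the molecule; the two known steps, a step that the two limits leave unreadable from compound 1 to compound 2 and a step that the two limits leave unreadable from compound 1 to compound 3, concern other changes and are themselves unreadable. The series therefore gives no ground for a step in either direction, and a further limit is the likeliest outcome. Expected is a number no higher from compound 3 to compound 4 (the limit leaves the size open). Compound 4 is estimated at 26000 nM in this assay, within a range from 10000 nM to 100000 nM.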

Compound 4, half-maximal effective concentration: > 26000 nM
Compound 4: no number, only a limit; the forecaster's own chance of this, stated with the estimate: 85%; the middle value sits exactly at the limit.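

No step can be read from compound 3 to compound 4 in this assay, because both stand at a limit of the assay: the limit of > 26000 nM in this assay, at which 4 of the 4 values shown sit.

Compounds 1 to 4 leave open at what concentration any of them would give an effect, and whether their structural differences change it.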